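Replacing an Amide Group with a Fluorinated Ester

The source may hold more compounds than are shown below. What is called first, only, known or untested is meant among the compounds shown, and "the series" means these compounds.

compound 1 `CCNC(=O)/C=C(C)/C=C/C(F)=C(C)/C=C/c1c(C)cc(OC)c(C)c1C`: 53%
compound 2 `COC(=O)/C=C(C)/C=C/C(F)=C(C)/C=C/C1=C(C)CCCC1(C)C`: 60%

In a functional assay on the whole organism (strain Hart Swiss) with Mus musculus as the target, with stated times of 5 days and 2 weeks, at a dose of 80 mg/kg by the intraperitoneal route (a higher number here means a stronger effect of the compound at the dose given, a lower number a weaker effect), compound 1 gives 53% and compound 2 gives 60%; the two values lie within the usual scatter of each other, so neither stands apart. Compound 3 `CCOC(=O)/C(F)=C(C)/C=C/C(F)=C(C)/C=C/c1c(C)cc(OC)c(C)c1C` differs from compound 1 by a group of 9 heavy atoms (6 carbon, 2 oxygen, 1 fluorine; no ring) in place of a group of 8 heavy atoms (6 carbon, 1 nitrogen, 1 oxygen; no ring), on a double-bonded chain carbon bound to a double-bonded chain carbon. Among the measured compounds shown here, no two measured compounds differ in one place only, so no measured step guides this change, and both measured values sit close together. The step of a number 3 percentage points higher from compound 1 to compound 3 (within the scatter) is expected to be small, not beyond the scatter. Compound 3 is estimated to give 56%, between 36% and 76%.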

Compound 3, a percentage reported as activity, at one dose (the size of the read-out at that dose, not a potency): 35%
Compound 3: middle estimate off by 21 percentage points, on the high side, and the stated range ends above it.
By their numbers in this assay, from the lowest: compound 3; then compounds 1 and 2 (each within the scatter of the next).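

In this assay, among the compounds shown here, this is the first step that can be read at this position, and a number 18 percentage points lower from compound 1 to compound 3 (beyond the scatter) shows that the change from the amide-bearing group to the group of 9 heavy atoms on a double-bonded chain carbon bound to a double-bonded chain carbon is not neutral. Compound 1 and compound 2 differ in more than one place and could not show this. No measurement at hand bears on the reason for the step.

The oxygen and fluorine of the entering group arrive together, so the compounds shown do not separate their contributions. On these data alone, how a carboxylic acid at this place would read also remains open.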